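Swapping Iodo for Dimethylamino in Compound 4

The source may hold more compounds than are shown below. What is called first, only, known or untested is meant among the compounds shown, and "the series" means these compounds.

Three compounds that share a (2-hydroxyethoxy)methyl group have been tested in a functional assay on L1210 cells (Mus musculus) for inhibition; a lower number here means a stronger inhibitor, a higher number a weaker inhibitor. Compound 1 `O=c1cc(O)ccn1COCCO` gives only a limit in this assay, > 1000 ug/mL. Compound 2 `Nc1nc(Cl)c2ncn(COCCO)c2n1` likewise gives only a limit in this assay, > 1000 ug/mL. Compound 3 `Nc1nc2c(nc(I)n2COCCO)c(=O)[nH]1` also reaches only a limit in this assay, > 1000 ug/mL. Compound 3 therefore stands exactly where the other two stand: at the limit of > 1000 ug/mL in this assay, at which 3 of the 3 values shown sit. Within the data shown here, since every value is a limit rather than a number, no step between measured compounds can be read off.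

Compound 4 `CN(C)c1nc2c(=O)[nH]c(N)nc2n1COCCO` has not yet been measured. It differs from compound 3 in one place: dimethylamino in place of iodo on an aromatic carbon. Among the measured compounds shown here, because all three measured values sit at the limit of > 1000 ug/mL in this assay, at which 3 of the 3 values shown sit, there is no measured step to lean on, and the expectation rests on that shared limit alone. For compound 4 the estimate in this assay is 1000 ug/mL, with a range from 300 ug/mL to 3000 ug/mL. The expected step of a number no higher from compound 3 to compound 4 (the limit leaves the size open) is thus close to none beyond the scatter, most likely once more a limit rather than a number.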

Compound 4, concentration for 50% inhibition: > 500 ug/mL
Compound 4 ended at the assay's limit; the forecaster's own chance of this, stated with the estimate: 80%; the middle value lies beyond the limit too.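

Compound 3 and compound 4 each give only a limit in this assay, not a number, and the step between them cannot be read. The compounds shown leave open how strongly any of them inhibits, and whether iodo or dimethylamino makes the stronger inhibitor.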